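The source may hold more compounds than are shown below. What is called first, only, known or untested is meant among the compounds shown, and "the series" means these compounds.

Compound 1 `CCCSc1nc(N/N=C/c2cccc(Cl)c2)c2nnn(Cc3ccccc3)c2n1` is the starting point of this step. In a functional assay on MGC-803 cells (Homo sapiens) for antiproliferative activity, read by MTT assay, with a stated time of 72 h (on this read-out lower numbers stand for stronger inhibition and higher numbers for weaker inhibition), compound 1 reaches only the limit of the measurement, > 64000 nM. Of the three values shown, compound 1 alone sits at the limit of > 64000 nM in this assay, at which 1 of the 3 values shown sits. Its two measured neighbours differ from it on the nitrogen on the aromatic ring: compound 2 `CCCSc1nc(N/N=C(\C)c2ccccc2O)c2nnn(Cc3ccccc3)c2n1` gives 2310 nM, and compound 3 `CCCSc1nc(N/N=C(\C)c2ccccc2)c2nnn(Cc3ccccc3)c2n1` gives 25400 nM. The step of an at least 27-fold lower number from compound 1 to compound 2 (1.44 log units; beyond the scatter) is the larger of the two, while an at least 2.5-fold lower number from compound 1 to compound 3 (0.40 log units; beyond the scatter) is smaller. Between the two hydrazone partners the step of an 11-fold higher number from compound 2 to compound 3 (1.04 log units; beyond the scatter) shows the weight of the hydroxy group alone.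

Compound 4 `CCCSc1nc(N/N=C/c2c(O)ccc3ccccc23)c2nnn(Cc3ccccc3)c2n1` departs from compound 1 by a single change: 2-hydroxynaphthalen-1-yl in place of 3-chlorophenyl on a carbon with a double bond to nitrogen. The new group carries the hydroxy group that compound 2 has and compound 3 lacks, and it extends the aromatic part by a second ring. Among the compounds with values here, since compound 2 moved far from the limit of compound 1 with an at least 27-fold lower number from compound 1 to compound 2 (1.44 log units; beyond the scatter), and the hydroxy group itself carried an 11-fold higher number from compound 2 to compound 3 (1.04 log units; beyond the scatter), a large downward step in this assay is expected here as well, though the second ring has no measured counterpart. Compound 4 is therefore expected to give about 3500 nM, within a range of 800 nM to 20000 nM. The expected change is an at least 18-fold lower number from compound 1 to compound 4 (1.26 log units; beyond the scatter).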

Compound 4, half-maximal inhibitory concentration: 3710 nM
For compound 4 the middle estimate is 1.1-fold (0.03 log units) below the measured one; low and high end bracket the measured number.
By their numbers in this assay, from the lowest: compounds 2 and 4 (each within the scatter of the next); then compound 3. At a limit, above all of these: compound 1.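

In this assay the change shows an at least 17-fold lower number from compound 1 to compound 4 (1.23 log units; beyond the scatter), made on a carbon with a double bond to nitrogen that keeps its hydrogen, whereas the steps to compound 2 and compound 3 also brought a methyl group onto that carbon, so among the compounds shown a methyl group there is not required for a large drop from the limit. As far as these compounds go, for compound 1, > 64000 nM is a limit and not a number, so the true size of the step stays unknown: the limit of > 64000 nM in this assay, at which 1 of the 4 values shown sits. Since 2-hydroxynaphthalen-1-yl replaces 3-chlorophenyl as a whole, the hydroxy group and the second ring enter together, and the step cannot be divided between them.

The compounds shown leave open how naphthalen-1-yl without the hydroxy group would read on this carbon, which would separate the part played by the second ring from that of the hydroxy group. They also leave open whether a methoxy group or an amine could take the place of the hydroxy group and give a similar number in this assay.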